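A few compounds are considered here, and "the series" means these few. Any claim that something is new, unique, unknown or untested is made for them only; others in the source may bear on it.

Of the compounds shown here, three have numbers so far in a functional assay on cells (Cancer cell lines, Homo sapiens) for inhibition; on this read-out lower numbers stand for stronger inhibition of growth and higher numbers for weaker inhibition of growth: compound 1 `Cc1cn2c(/C=N/Nc3ccccn3)c(-c3ccc(Cl)c([N+](=O)[O-])c3)nc2s1` gives 38900 nM, compound 2 `N=C(N)N/N=C/c1c(-c2cc(Cl)sc2Cl)nc2n1CCS2` gives 22900 nM, and compound 3 `Cc1cn2c(/C=N/NC(=N)N)c(-c3cccs3)nc2s1` gives 18600 nM. Compound 2 stands within the scatter of both compound 1 and compound 3, so no order can be read between it and either of them. Within the data shown here, no pair of measured compounds differs in one place only, so the series offers no direct measure of what a single change does.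

Compound 4 `N=C(N)N/N=C/c1c(-c2cccs2)nc2n1CCS2` keeps the core of compound 2 and has thiophen-2-yl in place of 2,5-dichlorothiophen-3-yl on an aromatic carbon. Among the measured compounds shown here, the only measured guide is compound 3, which bears thiophen-2-yl on a different core and gives 18600 nM in this assay, within the scatter of compound 2. On that slender evidence, the expected change is small, towards a slightly higher number, and not beyond the scatter. The estimated change is a 1.1-fold higher number from compound 2 to compound 4 (0.06 log units; within the scatter). The estimate for compound 4 is 26000 nM, with an expected range from 13000 nM to 60000 nM.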

Compound 4, concentration for total growth inhibition: 40700 nM
For compound 4 the middle estimate is 1.6-fold (0.19 log units) below the measured one; the range from low to high includes it.
By their numbers in this assay, from the lowest: compounds 3, 2, 1 and 4 (each within the scatter of the next, the first and the last beyond it).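

The first direct measure at this aromatic carbon comes from thiophen-2-yl in place of 2,5-dichlorothiophen-3-yl, which in this assay gives a 1.8-fold higher number from compound 2 to compound 4 (0.25 log units; within the scatter). As this step lies within the scatter, the two groups cannot be ranked at this position, and this single exchange shows no clear effect of dropping the two chlorine atoms and changing the thiophene attachment together. No supporting data are available to explain the result.

With both changes folded into one step, the compounds shown leave open what each does alone, which 2-chlorothiophen-3-yl or unsubstituted thiophen-3-yl on the core of compound 2 could separate. They also leave open whether a group of another kind on this carbon, such as an amine, a carboxylic acid or a longer alkyl chain, would move the number beyond the scatter.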